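Swapping the Aryl Group on a Weak Cell-Growth Inhibitor

A few compounds are considered here, and "the series" means these few. Any claim that something is new, unique, unknown or untested is made for them only; others in the source may bear on it.

Of the compounds shown here, three have been measured in a functional assay on MCF7 cells (Homo sapiens) for antiproliferative activity; a lower number here means a stronger inhibitor, a higher number a weaker inhibitor. Compound 2 `Cc1c(O)ccc2cc(-n3cc(-c4ccc(F)cc4F)nn3)c(=O)oc12` gives 33500 nM in this assay. Compound 1 `CO[C@@H]1[C@@H](O)[C@@H](O)[C@H](Oc2ccc3c(c2C)OC(=O)C(n2cc(-c4ccc(C)cc4)nn2)C3)OC1(C)C` reaches only the limit of > 100000 nM in this assay. Compound 3 `CC(=O)Oc1ccc2cc(-n3cc(-c4ccc(F)cc4F)nn3)c(=O)oc2c1C` likewise shows only the limit of > 100000 nM in this assay. Going by the values given here, compound 2 thus stands as the only compound with an actual number, the other two sitting at a limit (the limit of > 100000 nM in this assay, at which 2 of the 3 values shown sit). Among the compounds with values here, the single measured step, an at least 2.9-fold higher number from compound 2 to compound 3 (0.47 log units; beyond the scatter), shows that placing an acetyl on the oxygen of the aromatic ring weakens the compound.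

Compound 4 `Cc1c(O)ccc2cc(-n3cc(-c4ccc(N(C)C)cc4)nn3)c(=O)oc12` differs from compound 2 in another place: 4-(dimethylamino)phenyl in place of 2,4-difluorophenyl on an aromatic carbon. Within the data shown here, no measured step touches this part of the molecule; the one step known, from compound 2 to compound 3, concerns the oxygen on the aromatic ring and cannot be carried over. With no guidance, the expected result for compound 4 is a number close to that of compound 2, meaning a step of a 1.1-fold lower number from compound 2 to compound 4 (0.05 log units; within the scatter) that stays within the scatter. Compound 4 is therefore estimated at 30000 nM, with a likely range from 8000 nM to 100000 nM.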

Compound 4, half-maximal inhibitory concentration: > 100000 nM
Compound 4: a limit, no number (the forecaster's own chance of this, stated with the estimate: 25%); at least 3.3-fold (0.52 log units) between middle value and limit.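

At this position the aryl group matters, which the earlier step on the ring oxygen could not show: in this assay, 4-(dimethylamino)phenyl in place of 2,4-difluorophenyl gives an at least 2.9-fold higher number from compound 2 to compound 4 (0.47 log units; beyond the scatter). Compound 2 therefore loses its measurable value with either of two separate changes, acetyl on the oxygen or this new aryl group, so both parts of compound 2 count in this series. The real size of the new step cannot be read, because compound 4 sits at a limit, not at a number: the limit of > 100000 nM in this assay, at which 3 of the 4 values shown sit.

As far as these compounds go, it remains open how a plain phenyl or a phenyl with a single fluorine would behave at this position. Such groups could tell whether the fluorines of compound 2 are needed or the dimethylamino group of compound 4 does the harm.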